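A larger ester group in place of chloromethyl

The source may hold more compounds than are shown below. What is called first, only, known or untested is meant among the compounds shown, and "the series" means these compounds.

Compound 1 `C=C1C(=O)O[C@H]2CC3=C[C@H](C/C(C)=C/[C@@H](OC(=O)/C=C/c4ccccc4)[C@H]12)OC3=O` and compound 2 `C=C1C(=O)O[C@H]2CC3=C[C@H](C/C(C)=C/[C@@H](OC(=O)/C=C/c4ccc(N(C)C)cc4)[C@H]12)OC3=O` and compound 3 `C=C1C(=O)O[C@H]2CC3=C[C@H](C/C(C)=C/[C@@H](OC(=O)CCl)[C@H]12)OC3=O` share one core and differ in the group on a carbonyl carbon. In a functional assay on A549 cells (Homo sapiens) for cytotoxicity, read by MTT assay, with a stated time of 48 h (a lower number here means a stronger inhibitor, a higher number a weaker inhibitor), compound 1 gives 4800 nM as a true number. Compound 2 gives > 10000 nM which is a limit of the assay and not a number. Compound 3 gives > 10000 nM which is also only a limit.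

The next structure is compound 4 `C=C1C(=O)O[C@H]2CC3=C[C@H](C/C(C)=C/[C@@H](OC(=O)C45CCC(C)(C(=O)O4)C5(C)C)[C@H]12)OC3=O` and the change is a group of 11 heavy atoms (9 carbon, 2 oxygen; one five-membered non-aromatic ring of carbon only, one five-membered non-aromatic ring with 1 hetero atom) in place of a group of 2 heavy atoms (1 carbon, 1 chlorine; no ring), on a carbonyl carbon on that same carbonyl carbon. The incoming group holds one five-membered non-aromatic ring of carbon only and one five-membered non-aromatic ring with 1 hetero atom.

Among the measured compounds shown here, two measured steps touch this carbonyl carbon. The step of an at least 2.0-fold higher number from compound 1 to compound 3 (0.31 log units; beyond the scatter) is at least modest and lies beyond the scatter, so the group here can matter. The step that the two limits leave unreadable from compound 2 to compound 3 has no readable size. The step of an at least 2.0-fold higher number from compound 1 to compound 2 (0.31 log units; beyond the scatter) is also at least modest. None of these steps involves a group like the new one, so a clear move in this assay in either direction is not expected. The expected outcome is a step that the limit leaves unreadable from compound 3 to compound 4 as a rough estimate. The estimate for compound 4 is 12000 nM with an expected range from 4000 nM to 30000 nM in this test.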

Compound 4, half-maximal inhibitory concentration: 3400 nM
Compound 4: the middle estimate sits 3.5-fold (0.55 log units) above what was measured, outside the stated range (below it).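

Compound 4 shows that this carbonyl carbon can carry a group with no aromatic ring and still give a true number in this assay, so a measurable value here does not depend on the 2-phenylethenyl group. Replacing chloromethyl with the new group gives an at least 2.9-fold lower number from compound 3 to compound 4 (0.46 log units; beyond the scatter), and replacing the 2-(4-(dimethylamino)phenyl)ethenyl group with it gives an at least 2.9-fold lower number from compound 2 to compound 4 (0.46 log units; beyond the scatter), while the comparison with the plain 2-phenylethenyl group gives a 1.4-fold lower number from compound 1 to compound 4 (0.15 log units; within the scatter). The step between compound 2 and compound 3 cannot be read, and the two steps to compound 4 from those compounds give only a minimum size, as both starting points are limits of the assay and not numbers: the limit of > 10000 nM in this assay, at which 2 of the 4 values shown sit.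

The compounds shown leave open which part of the new group matters, for instance whether a plain cyclopentyl group, holding only a five-membered ring of carbon, would read like compound 4. They also leave open how a longer chain ending in an amine or a carboxylic acid on this carbonyl carbon would read.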